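A few compounds are considered here, and "the series" means these few. Any claim that something is new, unique, unknown or untested is made for them only; others in the source may bear on it.

Three compounds share one core and differ only in the aryl group carried by an amine nitrogen in a ring: compound 1 `Nc1scc(CN2CCN(c3cccc(Cl)c3Cl)CC2)c1C(=O)c1ccc(Cl)cc1`, compound 2 `Nc1scc(CN2CCN(c3cc(Cl)cc(Cl)c3)CC2)c1C(=O)c1ccc(Cl)cc1` and compound 3 `Nc1scc(CN2CCN(c3ccc(Cl)cc3F)CC2)c1C(=O)c1ccc(Cl)cc1`. In an assay on CHO cells for displacement of a labelled ligand from adenosine receptor A3 (Homo sapiens), read by scintillation counting, with a stated time of 120 min, tested at 10 uM (on this read-out lower numbers stand for less inhibition and higher numbers for more inhibition at the one concentration tested (going by the name of the read-out)), compound 1 gives 0%, compound 2 gives 1% and compound 3 gives 1%. Compound 3 thus sits level with compound 2, and its gap to compound 1 lies within the usual scatter. Every measured step, a number 1 percentage points higher from compound 1 to compound 2 (within the scatter), a number 1 percentage points higher from compound 1 to compound 3 (within the scatter) and no change at the digits printed from compound 2 to compound 3 (within the scatter), is within that scatter, so swapping one aryl group for another has so far left this assay flat. Compound 4 `Nc1scc(CN2CCN(c3cccc(C(F)(F)F)c3)CC2)c1C(=O)c1ccc(Cl)cc1` carries the change (3-(trifluoromethyl)phenyl in place of 4-chloro-2-fluorophenyl on an amine nitrogen in a ring). With every comparable step flat, the expected step of a number 1 percentage points higher from compound 3 to compound 4 (within the scatter) is none beyond the scatter, and compound 4 is estimated at 2%, between -5% and 12%.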

Compound 4, a percentage reported as inhibition, at one concentration (the size of the read-out at that concentration, not a potency): 0%
Estimate against measurement, compound 4: 2 percentage points above; the measured number falls inside the stated range.
By their numbers in this assay, from the lowest: compounds 1, 4, 2 and 3 (each within the scatter of the next).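

Swapping in 3-(trifluoromethyl)phenyl at this position moves nothing in this assay: the steps are a number 1 percentage points lower from compound 3 to compound 4 (within the scatter) and a number 1 percentage points lower from compound 2 to compound 4 (within the scatter) and no change at the digits printed from compound 1 to compound 4 (within the scatter) on the same shared core. The flat picture therefore now covers an aryl group with trifluoromethyl and no chlorine, as well as the halogen-only rings of compounds 1 to 3. No evidence here accounts for this flatness. From the compounds shown here alone, whether any group on this nitrogen can raise the number remains open, for example a benzyl group or a pyridine ring. The compounds shown also leave open what changes elsewhere on the core would do.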